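The source may report more compounds than this note shows. Statements on the series, on what has been measured and on what is new or still open speak of the compounds shown alone.

Compound 1 `CC(C)N(CC[C@H](N)C(=O)O)C[C@H]1O[C@@H](n2cnc3c(N)ncnc32)[C@H](O)[C@@H]1O` holds the higher of the two numbers measured in an assay for inhibition of tRNA (cytosine(38)-C(5))-methyltransferase (Homo sapiens), with a stated time of 5 min, tested at 100 uM; a lower number here means less inhibition, a higher number more inhibition at the concentration tested (going by the name of the read-out): in that assay compound 1 gives 44%. Among the compounds with values here, its only measured neighbour is compound 2 `Nc1ncnc2c1ncn2[C@@H]1O[C@H](CN(CC[C@H](N)C(=O)O)CC2CCC2)[C@@H](O)[C@H]1O`, which in this assay gives 32%. Within the data shown here, the single measured step, a number 12 percentage points lower from compound 1 to compound 2 (beyond the scatter), came with cyclobutylmethyl in place of isopropyl on an amine nitrogen.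

Compound 3 `Nc1ncnc2c1ncn2[C@@H]1O[C@H](CN(CC[C@H](N)C(=O)O)Cc2ccccc2)[C@@H](O)[C@H]1O` has not yet been measured in this assay. It differs from compound 1 by benzyl in place of isopropyl on an amine nitrogen. The step from compound 1 to compound 2 is the only one that bears on this change, since it too replaced isopropyl on the same amine nitrogen, and it was a modest drop beyond the scatter. A comparable modest lowering is therefore expected for compound 3, namely a number 12 percentage points lower from compound 1 to compound 3 (beyond the scatter). In this assay compound 3 is expected to give 32%, with a likely range from 18% to 46%.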

Compound 3, a percentage reported as inhibition, at one concentration (the size of the read-out at that concentration, not a potency): 56.8%
Compound 3: the middle estimate sits 24.8 percentage points below what was measured; measured number above the stated range.
By their numbers in this assay, from the lowest: compound 2; then compound 1; then compound 3.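

In this assay, replacing isopropyl on this amine nitrogen does not lower the number as a rule: benzyl in place of isopropyl gave a number 12.8 percentage points higher from compound 1 to compound 3 (beyond the scatter), the opposite direction to a number 12 percentage points lower from compound 1 to compound 2 (beyond the scatter). The ring carried on the saturated chain carbon bound to the amine nitrogen also matters, as phenyl in place of cyclobutyl gave a number 24.8 percentage points higher from compound 2 to compound 3 (beyond the scatter), the largest step among these compounds. Nothing measured here explains why the phenyl and cyclobutyl rings part in this way.

On these data alone, it remains open whether a longer chain, such as phenethyl, would keep the gain seen with benzyl. Also open, as far as these compounds go, is how a benzyl carrying a methoxy group or a fluorine atom on its ring would compare with compound 3.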